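The source may hold more compounds than are shown below. What is called first, only, known or untested is meant among the compounds shown, and "the series" means these compounds.

Measured compounds:
- compound 1 `Cc1ccc(S(=O)(=O)/N=C(/CCNC2=CC(=O)c3ccccc3C2=O)Nc2ccccc2I)cc1` gives 49400 nM
- compound 2 `COc1cc(N/C(CCNC2=CC(=O)c3ccccc3C2=O)=N\S(=O)(=O)c2ccc(C)cc2)cc(OC)c1OC` gives 75800 nM

For the measured compounds named here, in an ADME assay on HEK293 cells (Homo sapiens) for cytotoxicity, read by MTT assay, with a stated time of 48 h (on this read-out higher numbers stand for weaker inhibition and lower numbers for stronger inhibition), compound 2 gives 75800 nM, and the one other number, from compound 1, sits within the scatter of it: the change a 1.5-fold higher number from compound 1 to compound 2 (0.19 log units; within the scatter) is too small to count as a difference.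

Compound 3 `Cc1ccc(S(=O)(=O)/N=C(/CCNC2=CC(=O)c3ccccc3C2=O)NCc2ccccc2)cc1` has not yet been measured in this assay. Compared with compound 2 it carries benzyl in place of 3,4,5-trimethoxyphenyl on an amine nitrogen. Going by the values given here, only one measured step exists, and it bears on this change only loosely: swapping one aryl group for another on the same amine nitrogen, from compound 1 to compound 2, moved the number by a 1.5-fold higher number from compound 1 to compound 2 (0.19 log units; within the scatter), which is within the scatter. Among the compounds with values here, there is no measured step that exchanges an aryl group for a benzyl group, so no direction can be drawn from the data.

The expectation is therefore a step of a 1.3-fold lower number from compound 2 to compound 3 (0.10 log units; within the scatter), that is, nothing beyond the scatter. Compound 3 is estimated at 60000 nM, with a likely range from 25000 nM to 150000 nM.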

Compound 3, half-maximal inhibitory concentration: 80200 nM
For compound 3 the middle estimate is 1.3-fold (0.13 log units) below the measured one; low and high end bracket the measured number.
By their numbers in this assay, from the lowest: compounds 1, 2 and 3 (each within the scatter of the next).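

In this assay the change to benzyl on this amine nitrogen gives a 1.1-fold higher number from compound 2 to compound 3 (0.02 log units; within the scatter) and a 1.6-fold higher number from compound 1 to compound 3 (0.21 log units; within the scatter) and both steps lie within the scatter. The earlier pair compared only 2-iodophenyl with 3,4,5-trimethoxyphenyl, so this result extends the comparison to a third group that carries neither iodine nor oxygen, and the three compounds still cannot be told apart in this cell test. Nothing measured here offers an explanation for how closely these numbers agree.

Still open, going by these compounds, is whether a different kind of group on this nitrogen, such as a small methyl, an aminoethyl chain or a group bearing a carboxylic acid, would give a number beyond the scatter. The compounds shown also cannot say whether changes elsewhere on the shared core would move the number.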